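The compounds below may be only part of what the source reports. "The series", "measured", "known", "first", "only" and "open" are said of these compounds alone.

In an ADME assay on SW480 cells (Homo sapiens) for cytotoxicity, read by MTT assay, with a stated time of 72 h (on this read-out higher numbers stand for weaker inhibition and lower numbers for stronger inhibition), compound 1 `CCc1cccc(NC(=O)c2cccc(/C=C3\CC(=O)N(c4ccccc4)C3=O)c2)c1` gives 88600 nM. Compound 2 `COc1ccc(OC)c(NC(=O)c2cccc(/C=C3\CC(=O)N(c4ccccc4)C3=O)c2)c1`, in this assay, reaches only the limit > 100000 nM, so for compound 2 a bound rather than a number is known (the limit of > 100000 nM in this assay, at which 1 of the 2 values shown sits). Going by the values given here, the one measured step, an at least 1.1-fold higher number from compound 1 to compound 2 (0.05 log units; that floor lies within the scatter), comes from putting 2,5-dimethoxyphenyl in place of 3-ethylphenyl on an amide-type nitrogen and lies within the scatter. Compound 3 `O=C(Nc1ccc(F)cc1)c1cccc(/C=C2\CC(=O)N(c3ccccc3)C2=O)c1` differs from compound 2 by 4-fluorophenyl in place of 2,5-dimethoxyphenyl on an amide-type nitrogen. Both changes swap one aromatic group on the same amide-type nitrogen, and the measured swap left the number essentially unchanged, so the expected step from compound 2 to compound 3 in this assay is none beyond the scatter, an at least 1.1-fold lower number from compound 2 to compound 3 (0.04 log units; that floor lies within the scatter). Compound 3 is therefore estimated at 90000 nM, with a range from 40000 nM to 200000 nM, and a real chance that only a limit is reported.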

Compound 3, half-maximal inhibitory concentration: > 100000 nM
Compound 3 was reported as a limit (the forecaster's own chance of this, stated with the estimate: 45%); middle value at least 1.1-fold (0.04 log units) away from the limit.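

In this assay a third aromatic group on the amide-type nitrogen, 4-fluorophenyl, behaves no differently from the first two as far as the data can tell. Putting it in place of 3-ethylphenyl gives an at least 1.1-fold higher number from compound 1 to compound 3 (0.05 log units; that floor lies within the scatter), so the floor of this step does not separate the two compounds, and the step between the two limits cannot be read. Compound 3 is reported only as a limit, as compound 2 was, and the limit is now shared: the limit of > 100000 nM in this assay, at which 2 of the 3 values shown sit.

The compounds shown leave open how far compound 2 and compound 3 truly lie from compound 1, and whether any group on this nitrogen can bring the number clearly down. An aminophenyl or carboxyphenyl group, or a longer alkyl chain in place of the aromatic ring, would test this.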